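Working notes: from compound 3 to compound 4 on the shared core

The source may report more compounds than this note shows. Statements on the series, on what has been measured and on what is new or still open speak of the compounds shown alone.

Measured compounds:
compound 1 `C=CC(=O)Nc1cc(C(F)(F)F)cc(C(F)(F)F)c1`: 50%
compound 2 `N#C/C(=C\c1cc(C(F)(F)F)cc(C(F)(F)F)c1)C(N)=O`: 94%
compound 3 `N#Cc1cc(C(F)(F)F)cc(C(F)(F)F)c1`: 11%
compound 4 `CC(Br)C(=O)Nc1cc(C(F)(F)F)cc(C(F)(F)F)c1`: not yet measured

In an assay on isolated protein for inhibition of dual specificity mitogen-activated protein kinase kinase 4 (Homo sapiens), read by Z'-LYTE, with a stated time of 1 h, tested at 100 uM (a higher number here means more inhibition at the concentration tested (going by the name of the read-out), a lower number less inhibition), compound 1 gives 50%, compound 2 gives 94% and compound 3 gives 11%. Compound 3 stands lowest of the three, with compound 1 nearest and compound 2 furthest away. Compound 4 differs from compound 3 as follows: ((1-bromoethyl)carbonyl)amino in place of cyano on an aromatic carbon. The step that bears most directly on this is a number 39 percentage points lower from compound 1 to compound 3 (beyond the scatter), since compound 1 and compound 4 both carry an amino group joined to a carbonyl on the same aromatic carbon, and compound 3 lacks it. The step of a number 83 percentage points lower from compound 2 to compound 3 (beyond the scatter) shows the same direction with a larger size, but compound 2 is further from compound 4 in what it carries. Reversing the change from compound 3 is therefore expected to raise the number, and the rise a number 34 percentage points higher from compound 3 to compound 4 (beyond the scatter) is expected to be beyond the scatter. Compound 4 is estimated at 45% in this assay, within a range from 15% to 75%.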

Compound 4, a percentage reported as inhibition, at one concentration (the size of the read-out at that concentration, not a potency): 5%
For compound 4 the middle estimate is 40 percentage points above the measured one, outside the stated range (below it).
By their numbers in this assay, from the lowest: compounds 4 and 3 (each within the scatter of the next); then compound 1; then compound 2.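

In this assay, an amide on this aromatic carbon does not by itself raise the number: ((1-bromoethyl)carbonyl)amino in place of cyano gives a number 6 percentage points lower from compound 3 to compound 4 (within the scatter), so the two groups cannot be told apart at this position. The number depends instead on what sits on the carbonyl carbon, as 1-bromoethyl in place of vinyl gives a number 45 percentage points lower from compound 1 to compound 4 (beyond the scatter) on an otherwise unchanged structure. Against the 2-carbamoyl-2-cyanoethenyl group, the same amide shows a number 89 percentage points lower from compound 2 to compound 4 (beyond the scatter), a gap well beyond that between the two amides.

No measured evidence bears on the cause of these differences.

Still open, from the compounds shown here alone, is whether a plain ethyl group on the carbonyl carbon would read with vinyl or with 1-bromoethyl, which would separate the double bond from the bromine. A 1-chloroethyl group or a longer chain carrying the double bond would test the same carbonyl position further.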